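One Amine Substitution, Two Cores, One Expected Step

A few compounds are considered here, and "the series" means these few. Any claim that something is new, unique, unknown or untested is made for them only; others in the source may bear on it.

Compound 1 `c1cc(CC2CCCNC2)c2occc2c1` and compound 2 `c1cc(CC2CCCNC2)c2ccoc2c1` are built from the same atoms joined differently; the difference between the two cores is not broken down here. In an assay for inhibition of Polycomb protein EED (Homo sapiens), read by LC-MS, with a stated time of 2 h (a higher number here means a weaker inhibitor, a lower number a stronger inhibitor), compound 1 gives 95000 nM, while compound 2 gives 40000 nM. Compound 3 `N=C(N)N1CCCC(Cc2cccc3ccoc23)C1` differs from compound 1 by a group of 3 heavy atoms (1 carbon, 2 nitrogen; no ring) in place of a hydrogen atom, on an amine nitrogen in a ring, and in this assay compound 3 gives 2800 nM, a step of a 34-fold lower number from compound 1 to compound 3 (1.53 log units; beyond the scatter). Compound 4 `N=C(N)N1CCCC(Cc2cccc3occc23)C1` carries the same change on the core of compound 2, namely (a group of 3 heavy atoms (1 carbon, 2 nitrogen; no ring) in place of a hydrogen atom, on an amine nitrogen in a ring). Because the same change on compound 1 gave a 34-fold lower number from compound 1 to compound 3 (1.53 log units; beyond the scatter), the step in this assay is expected to be a 33-fold lower number from compound 2 to compound 4 (1.52 log units; beyond the scatter). Compound 4 is therefore estimated to give about 1200 nM in this assay, expected to fall between 400 nM and 4000 nM.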

Compound 4, half-maximal inhibitory concentration in the Polycomb protein EED assay: 2100 nM
Estimate against measurement, compound 4: 1.8-fold (0.24 log units) below, and the stated range covers the measured number.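

In the Polycomb protein EED assay compound 4 gives 2100 nM; the change on the amine nitrogen in the ring gives a 19-fold lower number from compound 2 to compound 4 (1.28 log units; beyond the scatter), and the step carries from one core to the other with no difference beyond the scatter: the same change on two cores in the Polycomb protein EED assay, a 34-fold lower number (1.53 log units; beyond the scatter) from compound 1 to compound 3 and a 19-fold lower number (1.28 log units; beyond the scatter) from compound 2 to compound 4, 1.8-fold (0.25 log units) apart, within the scatter of two such steps

In a physicochemical assay for acid dissociation, using potentiometric titration, compound 2 gives 9.8. In the physicochemical assay compound 4 gives > 11, which is a limit of the assay and not a number. These results rest on two cores only, and they do not show whether the lower number in the Polycomb protein EED assay is tied to the acid dissociation constant.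

From the compounds shown here alone, it remains open whether a methyl group or an acetyl amide on the same ring nitrogen would give a step of like size. Going by these compounds, it also remains open whether the step would hold on a third core.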